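The source may report more compounds than this note shows. Statements on the series, on what has been measured and on what is new or still open speak of the compounds shown alone.

Compound 1 `CCn1cc(-c2nc3ccc([N+](=O)[O-])cc3s2)c(=O)c2cc(F)c(N3CCNCC3)cc21` is the most potent of the three measured compounds: in a functional assay on A2780 cells (Homo sapiens) for cytotoxicity, read by MTT assay, with a stated time of 48 h (on this read-out lower numbers stand for stronger inhibition and higher numbers for weaker inhibition), compound 1 gives 700 nM. Compound 2 `CCn1cc(-c2nc3ccc([N+](=O)[O-])cc3s2)c(=O)c2cc(F)c(N3CCN(C)CC3)cc21` carries the change (methyl in place of hydrogen on an amine nitrogen in a ring), and in this assay compound 2 gives 4300 nM, which is a 6.1-fold higher number from compound 1 to compound 2 (0.79 log units; beyond the scatter). Compound 3 `CCn1cc(-c2nc3ccc(N)cc3[nH]2)c(=O)c2cc(F)c(N3CCNCC3)cc21` has a different core; the difference between the two cores is not broken down here. In this assay compound 3 gives 51500 nM, the highest number of the three. Compound 4 `CCn1cc(-c2nc3ccc(N)cc3[nH]2)c(=O)c2cc(F)c(N3CCN(C)CC3)cc21` differs from compound 3 by methyl in place of hydrogen on an amine nitrogen in a ring, the same change as from compound 1 to compound 2. Because the earlier step was a 6.1-fold higher number from compound 1 to compound 2 (0.79 log units; beyond the scatter), a similar step is expected here, so the step from compound 3 to compound 4 is estimated as a 4.9-fold higher number from compound 3 to compound 4 (0.69 log units; beyond the scatter). In this assay compound 4 is therefore expected to give about 250000 nM, with a plausible range from 80000 nM to 800000 nM.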

Compound 4, half-maximal inhibitory concentration: > 50000 nM
Compound 4: only a limit was reported; the forecaster's own chance of this, stated with the estimate: 40%; the middle value does not contradict the limit.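

In this assay compound 4 gives > 50000 nM, which is a limit and not a number. The step from compound 3 to compound 4 therefore cannot be read. The compounds shown leave open how large the methyl change is on the core of compound 3.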